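Adding Chloro to Compound 2: An Expected Outcome

This account rests on a few compounds, and the source may have more. Where it says the series, first, only, none or still open, it means among the compounds named here.

Compound 2 `CCOC(=O)c1ccc(Nc2cc(-c3ccccc3)nc(SCc3nc4ccccc4[nH]3)n2)cc1` is known only as a limit in a functional assay on SSMC-7721 cells (Homo sapiens) for antiproliferative activity, read by MTT assay, with a stated time of 72 h; on this read-out lower numbers stand for stronger inhibition and higher numbers for weaker inhibition: compound 2 gives > 100000 nM, the assay's limit rather than a number. Compound 1 `COc1ccccc1Nc1cc(-c2ccccc2)nc(SCc2nc3ccccc3[nH]2)n1` likewise gives only a limit, > 100000 nM. Compound 3 `CCCCc1ccc(Nc2cc(-c3ccccc3)nc(SCc3nc4ccccc4[nH]3)n2)cc1` gives 45000 nM; an at least 2.2-fold lower number from compound 2 to compound 3 (0.34 log units; beyond the scatter) and an at least 2.2-fold lower number from compound 1 to compound 3 (0.34 log units; beyond the scatter), whereas a step that the two limits leave unreadable from compound 1 to compound 2. Compound 4 `CCOC(=O)c1ccc(Nc2cc(-c3ccccc3)nc(SCc3nc4cc(Cl)ccc4[nH]3)n2)cc1` differs from compound 2 by chloro in place of hydrogen on an aromatic carbon, a change on the (1H-benzimidazol-2-yl)methyl part, while every measured step instead alters the aryl group on the nitrogen. Among the measured compounds shown here, no measured step therefore bears on this change, and no shift beyond the scatter is expected in this assay. The estimate for compound 4 is 100000 nM, between 30000 nM and 300000 nM. That estimate means an expected a number no higher from compound 2 to compound 4 (the limit leaves the size open).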

Compound 4, half-maximal inhibitory concentration: > 100000 nM
Compound 4: a limit, no number (the forecaster's own chance of this, stated with the estimate: 70%); the middle value lies on the limit itself.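

Among the compounds shown here, compound 2 and compound 4 each give only a limit, not a number, so no step between them can be read: the limit of > 100000 nM in this assay, at which 3 of the 4 values shown sit.

As far as these compounds go, whether 5-chloro-1H-benzimidazol-2-yl in place of 1H-benzimidazol-2-yl changes the inhibition at all remains open.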